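Methoxy removal on the aryl ring of compound 1

This account rests on a few compounds, and the source may have more. Where it says the series, first, only, none or still open, it means among the compounds named here.

Measured compounds in a functional assay on MCF7 cells (Homo sapiens) for cytotoxicity, read by MTT assay, with a stated time of 4 h; a higher number here means a weaker inhibitor, a lower number a stronger inhibitor:
compound 1 `COc1ccc(/C=C2/SC(NN3Cc4ccccc4N=C3c3ccccc3)=NC2=O)cc1OC` gives 1000 nM
compound 2 `O=C(CNc1ccc(Br)cc1)Nn1c(-c2ccccc2)nc2ccccc2c1=O` gives 15100 nM
compound 3 `O=C(CNc1ccccc1)Nn1c(-c2ccccc2)nc2ccccc2c1=O` gives 15300 nM

Compound 1 stands at the lowest number of the three in this assay; compound 2 and compound 3 both sit far higher, and they share a core different from that of compound 1. Within the data shown here, the one step that can be followed within the measured set runs on that other core: a 1.0-fold higher number from compound 2 to compound 3 (0.01 log units; within the scatter). Among the measured compounds shown here, it is the only paired comparison available, and it concerns a different group on a different scaffold.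

Compound 4 `COc1ccc(/C=C2/SC(NN3Cc4ccccc4N=C3c3ccccc3)=NC2=O)cc1` is the unmeasured analogue of compound 1. The change is hydrogen in place of methoxy on an aromatic carbon. For the measured compounds named here, no measured step touches this position or this group, so the expectation rests on the size of the one known step and on the value of compound 1 itself. Going by the values given here, the single step known to the series is within the scatter, and a change of a small group on an aromatic carbon is the nearest precedent; the expected step is therefore small, if anything toward a slightly higher number, a 1.5-fold higher number from compound 1 to compound 4 (0.18 log units; within the scatter). Compound 4 is thus estimated at 1500 nM in this assay, with a range from 500 nM to 5000 nM.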

Compound 4, half-maximal inhibitory concentration: 3760 nM
Compound 4: middle estimate off by 2.5-fold (0.40 log units), on the low side, within the range that was stated.
By their numbers in this assay, from the lowest: compound 1; then compound 4; then compounds 2 and 3 (each within the scatter of the next).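

In this assay, the change from 3,4-dimethoxyphenyl to 4-methoxyphenyl produces a step beyond the scatter (a 3.8-fold higher number from compound 1 to compound 4 (0.58 log units; beyond the scatter)), so the methoxy group on this aromatic carbon contributes to the lower number of compound 1, though the step is modest. Among these compounds, the only earlier step, hydrogen in place of bromo on the other core (a 1.0-fold higher number from compound 2 to compound 3 (0.01 log units; within the scatter)), lies within the scatter and gave no sign that a single aromatic substituent could move the number; this result shows that one can on the core of compound 1, at this position and with this group. No available measurement accounts for the size of the step.

The compounds shown leave open whether the step depends on oxygen at this aromatic carbon or on the group as a whole, which a hydroxy group, a fluorine atom or a longer ethoxy chain in its place would help to separate. They also leave open how the remaining methoxy group, ortho to the position in compound 1, contributes on its own, and whether the same exchange would give a comparable step on the core of compound 2 and compound 3.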